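Cyclopentylamino on the pyridine of the tert-butyl anilide

A few compounds are considered here, and "the series" means these few. Any claim that something is new, unique, unknown or untested is made for them only; others in the source may bear on it.

Working notes on the biaryl amide series. In a functional assay for antagonist activity at transient receptor potential cation channel subfamily V member 1 (Rattus norvegicus) (on this read-out lower numbers stand for stronger inhibition and higher numbers for weaker inhibition), compound 3 `CC(C)(C)c1ccc(NC(=O)c2ccc(-c3ccccn3)cc2)cc1` gives 8 nM and stands lowest of the two numbers given; the nearest is compound 1 `N#Cc1ccc(NC(=O)c2ccc(-c3ncccc3C(F)(F)F)cc2)cc1`, which in this assay gives 1300 nM, a gap beyond the scatter. Compound 2 `Cc1cccnc1-c1ccc(C(=O)Nc2ccc(F)cc2)cc1` reaches only the assay limit (the limit of > 4000 nM in this assay, at which 1 of the 3 values shown sits), giving > 4000 nM in this assay. Compound 4 `CC(C)(C)c1ccc(NC(=O)c2ccc(-c3ncccc3NC3CCCC3)cc2)cc1` differs from compound 3 by cyclopentylamino in place of hydrogen on an aromatic carbon, the group sitting two atoms from the ring nitrogen. Among the measured compounds shown here, no measured pair isolates this change; compounds 1 and 2 carry other groups at that carbon but also differ in the anilide, so their values say nothing separable about the pyridine substituent. A small step, if any, is expected: a 2.5-fold higher number from compound 3 to compound 4 (0.40 log units; beyond the scatter). Compound 4 is estimated at 20 nM in this assay, within 4 nM to 150 nM.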

Compound 4, half-maximal inhibitory concentration: 44 nM
Compound 4: the middle estimate sits 2.2-fold (0.34 log units) below what was measured; the measured number falls inside the stated range.
By their numbers in this assay, from the lowest: compound 3; then compound 4; then compound 1. At a limit, above all of these: compound 2.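

In this assay, cyclopentylamino on the aromatic carbon two atoms from the ring nitrogen gives a 5.5-fold higher number from compound 3 to compound 4 (0.74 log units; beyond the scatter). Among the compounds shown here, this is the first pair to isolate a change at this carbon, and it shows that the tert-butyl anilide tolerates this large group there with only a modest loss. Nothing measured here explains the size of this step.

Open, as far as these compounds go, is whether a plain amino group, methylamino or cyclopentyloxy at this carbon would behave alike. Also open, from the compounds shown here alone, is how methyl or trifluoromethyl there would fare on the tert-butyl anilide.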